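The source may hold more compounds than are shown below. What is called first, only, known or untested is meant among the compounds shown, and "the series" means these compounds.

In an ADME assay on Vero 76 cells (Chlorocebus sabaeus) for cytotoxicity, read by crystal violet staining, with a stated time of 96 h (a higher number here means that more compound is tolerated, a lower number that less compound is tolerated), three compounds that share one core have been measured. Compound 1 `CC(=O)NC(=S)Nc1cccc(C(F)(F)F)c1` reaches only a limit of the assay, > 100000 nM, so it gives no exact number. Compound 2 `Fc1cccc(NC(=S)Nc2cccc(C(F)(F)F)c2)c1` gives 20000 nM, and compound 3 `FC(F)(F)c1cccc(NC(=S)NCc2ccco2)c1` gives 50000 nM. Compound 3 is therefore the higher of the two exact numbers, and the gap is a 2.5-fold higher number from compound 2 to compound 3 (0.40 log units; beyond the scatter).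

The next change replaces (furan-2-yl)methyl with 2-bromophenyl on an amide-type nitrogen, giving compound 4 `FC(F)(F)c1cccc(NC(=S)Nc2ccccc2Br)c1`: 2-bromophenyl in place of (furan-2-yl)methyl on an amide-type nitrogen. The closest guide is compound 2, which carries 3-fluorophenyl at that place. Read in reverse, a 2.5-fold higher number from compound 2 to compound 3 (0.40 log units; beyond the scatter) suggests a modest fall on moving to a substituted phenyl group. In the same direction, an at least 5.0-fold lower number from compound 1 to compound 2 (0.69 log units; beyond the scatter). This rests on a single pair of exact numbers, and bromine is not fluorine, so the guide is only rough.

The expected change in this assay is a modest fall, a 2.5-fold lower number from compound 3 to compound 4 (0.40 log units; beyond the scatter). Compound 4 is estimated at 20000 nM, with an expected range of 7000 nM to 50000 nM.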

Compound 4, half-maximal cytotoxic concentration: 50000 nM
Compound 4: the middle estimate sits 2.5-fold (0.40 log units) below what was measured; measured number inside the range.
By their numbers in this assay, from the lowest: compound 2; then compounds 3 and 4 (each within the scatter of the next). At a limit, above all of these: compound 1.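

In this assay, a carbon-only six-membered aromatic ring in the form of 2-bromophenyl can stand on the amide-type nitrogen in place of (furan-2-yl)methyl without a measurable shift, with no change at the digits printed from compound 3 to compound 4 (within the scatter) (this pair shows that the ring type alone need not move the number). A substituted phenyl group therefore does not by itself bring the lower number seen with 3-fluorophenyl, as a 2.5-fold higher number from compound 2 to compound 4 (0.40 log units; beyond the scatter) (the two groups behave differently here). Compound 1 stands at a limit of the assay, so only a floor can be read (an at least 2.0-fold lower number from compound 1 to compound 4 (0.30 log units; that floor lies within the scatter)): (the limit of > 100000 nM in this assay, at which 1 of the 4 values shown sits).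

The compounds shown leave open how a plain phenyl group, a longer chain or a chain ending in an amine would fare on this nitrogen. They also cannot separate the effect of bromine from that of fluorine, since 2-bromophenyl and 3-fluorophenyl differ in more than the halogen.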